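This account rests on a few compounds, and the source may have more. Where it says the series, first, only, none or still open, it means among the compounds named here.

Measured so far:
- compound 1 `COc1ccc(C2CC(c3ccccc3)=NN2C(=O)c2ccco2)cc1`: > 50000 nM
- compound 2 `O=C(c1ccncc1)N1N=C(c2ccc(Cl)cc2)CC1c1ccco1`: 6500 nM
- compound 3 `COc1ccccc1C1=NN(C(=O)c2ccncc2)C(c2ccc([N+](=O)[O-])cc2)C1`: 7200 nM

All three were tested in a functional assay on BT-474 cells (Homo sapiens) for antiproliferative activity, read by CCK-8 assay, with a stated time of 72 h; a lower number here means a stronger inhibitor, a higher number a weaker inhibitor. Compound 1 gives > 50000 nM, which is a limit of the assay and not a number.

Compound 4 `COc1ccc(C2CC(c3ccccc3)=NN2C(=O)c2ccncc2)cc1` keeps the core of compound 1 and changes one group: pyridin-4-yl in place of furan-2-yl on a carbonyl carbon. In words, pyridin-4-yl stands in place of furan-2-yl on a carbonyl carbon.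

Compound 2, at 6500 nM, and compound 3, at 7200 nM, both carry the (pyridin-4-yl)carbonyl, although their other groups differ from those of compound 1. Going by the values given here, no measured pair isolates this change, so a move toward stronger inhibition in this assay, beyond the scatter, is only an expectation. The expected size is an at least 3.3-fold lower number from compound 1 to compound 4 (0.52 log units; beyond the scatter). Compound 4 is estimated at 15000 nM, with an expected range from 4000 nM to 50000 nM.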

Compound 4, half-maximal inhibitory concentration: > 50000 nM
Compound 4 ended at the assay's limit; the forecaster's own chance of this, stated with the estimate: 20%; at least 3.3-fold (0.52 log units) between middle value and limit.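

Compound 1 and compound 4 both sit at the limit of this assay, so no step can be read between them: the limit of > 50000 nM in this assay, at which 2 of the 4 values shown sit.

Still open, on these data alone, is whether pyridin-4-yl in place of furan-2-yl on a carbonyl carbon changes inhibition at all, and which other groups in compound 2 and compound 3 go with their measured values.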